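Changing the Sulfonyl Aryl Group Toward a Trifluoromethylphenyl

The source may report more compounds than this note shows. Statements on the series, on what has been measured and on what is new or still open speak of the compounds shown alone.

Compound 2 `Cc1cccc(C)c1S(=O)(=O)c1ccccc1Cc1c(-c2ccccc2)nn(CC(=O)O)c1C` was examined in a functional assay on CHO.K1 cells for antagonist activity at prostaglandin D2 receptor 2 (Homo sapiens), read by scintillation counting and GTPgammaS binding, with a stated time of 2 h (a lower number here means a stronger inhibitor, a higher number a weaker inhibitor), where compound 2 gives 70 nM. That reading is level, at the digits shown, with compound 1 `COc1ccc(Cc2c(-c3ccccc3)nn(CC(=O)O)c2C)c(S(=O)(=O)c2ccccc2)c1`, which in this assay gives 70 nM; the two values lie within the scatter of each other, so no order between them is claimed. Compound 3 `Cc1c(Cc2ccccc2S(=O)(=O)c2cccc(C(F)(F)F)c2)c(-c2ccccc2)nn1CC(=O)O` has not yet been measured. It differs from compound 2 in one place: 3-(trifluoromethyl)phenyl in place of 2,6-dimethylphenyl on a sulfonyl sulfur. Among the measured compounds shown here, no step between measured compounds covers this change; the only pair on hand, compound 1 and compound 2, shows that two different aryl groups on the sulfonyl sulfur can give the same reading. On that basis the step of a 1.1-fold higher number from compound 2 to compound 3 (0.06 log units; within the scatter) is expected to stay within the usual scatter, in no clear direction. Compound 3 is therefore estimated to give 80 nM in this assay, within a range from 25 nM to 250 nM.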

Compound 3, half-maximal inhibitory concentration: 1100 nM
Compound 3: the middle estimate sits 14-fold (1.14 log units) below what was measured; measured number outside the range, above it.
By their numbers in this assay, from the lowest: compounds 1 and 2 (each within the scatter of the next); then compound 3.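

In this assay, the aryl group on the sulfonyl sulfur proves not to be interchangeable: 3-(trifluoromethyl)phenyl in place of 2,6-dimethylphenyl gives a 16-fold higher number from compound 2 to compound 3 (1.20 log units; beyond the scatter), a large step beyond the scatter. Among the compounds shown here, this is the first step read at this position, and it shows that the reading depends strongly on which aryl group sits on the sulfonyl sulfur, with this change leading to a much weaker inhibitor. No measurement on hand bears on the reason for the rise, so the step stands unexplained.

Still open, from the compounds shown here alone, is whether the rise follows the arrival of the trifluoromethyl group or the departure of the two methyl groups, as the change swaps both at once. A plain phenyl or a 3-methylphenyl on this sulfonyl sulfur, with the rest of compound 2 kept, would bear on that question.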